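The source may hold more compounds than are shown below. What is called first, only, known or untested is meant among the compounds shown, and "the series" means these compounds.

Measured compounds:
Compound 1 `COc1ccc(CNc2nc([Se]C)nc3ccccc23)cc1` in a functional assay on HTB-54 cells (Homo sapiens) for cytotoxicity, read by MTT assay, with a stated time of 72 h; on this read-out lower numbers stand for stronger inhibition of growth and higher numbers for weaker inhibition of growth: 33000 nM
Compound 2 `COc1ccc(CNc2nc([SeH])nc3ccccc23)cc1` in this assay: 7110 nM
Compound 3 `[SeH]c1nc(NCc2ccccc2)c2cccnc2n1` in this assay: > 100000 nM, a limit of the assay and not a number.

Compound 2 holds the lowest of the two numbers given; the step from compound 1 to compound 2 is a 4.6-fold lower number from compound 1 to compound 2 (0.67 log units; beyond the scatter). Compound 3 sits at the limit of > 100000 nM in this assay, at which 1 of the 3 values shown sits, so it gives no number to compare.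

Compound 4 `CSc1ccc(CNc2nc([SeH])nc3ccccc23)cc1` differs from compound 2 by methylsulfanyl in place of methoxy on an aromatic carbon. Among the measured compounds shown here, none of the measured steps touches this position: the single measured step, a 4.6-fold lower number from compound 1 to compound 2 (0.67 log units; beyond the scatter), concerns the selenium substituent, and compound 3 contributes only a limit. For the measured compounds named here, with no measured step bearing on the change, the expectation for compound 4 is a step of no size beyond the scatter in this assay, that is a 1.0-fold lower number from compound 2 to compound 4 (0.01 log units; within the scatter). The estimate for compound 4 is therefore 7000 nM, with a range from 2500 nM to 20000 nM.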

Compound 4, concentration for 50% growth inhibition: 45500 nM
The estimate for compound 4 lay 6.5-fold (0.81 log units) below the measured number; the measured number lies above the stated range.
By their numbers in this assay, from the lowest: compound 2; then compounds 1 and 4 (each within the scatter of the next). At a limit, above all of these: compound 3.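

In this assay, the aromatic carbon para to a large group proves sensitive to the atom linking the methyl: methylsulfanyl in place of methoxy gives a 6.4-fold higher number from compound 2 to compound 4 (0.81 log units; beyond the scatter) on an otherwise unchanged structure. Among the compounds shown here, the earlier compounds showed a change only at the selenium, so this is the first sign that the substituent on this ring also moves the number, and here the methoxy of compound 2 is the better of the two groups. Nothing available bears on why this change has this effect.

Going by these compounds, whether the sensitivity extends to other groups at this position, such as an amine, a hydroxyl or a longer alkoxy chain, remains open. Also open, on these data alone, is whether the same change would act alike with methyl on the selenium, as in compound 1.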